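The source may report more compounds than this note shows. Statements on the series, on what has been measured and on what is new or still open speak of the compounds shown alone.

Compound 3 `Cc1cccc(-c2cn3ccnc3c(-c3ccc4ncn(Cc5ccccc5)c4c3)n2)c1` is the starting point of this step. In a functional assay on OVCAR-5 cells (Homo sapiens) for inhibition, read by sulforhodamine B assay, with a stated time of 48 h, tested at 10 uM (a higher number here means more inhibition at the concentration tested (going by the name of the read-out), a lower number less inhibition), compound 3 gives 6.64%. Compound 1 `Fc1ccccc1-c1cn2ccnc2c(-c2ccc3ncn(C4CCCCC4)c3c2)n1` gives 6.64% in the same assay, the same number at the digits shown, and the two together are the lowest of the three measured values. Compound 2 `CCc1ccc(-c2cn3ccnc3c(-c3ccc4ncn(Cc5ccccc5)c4c3)n2)cc1` gives 14.9%; the step of a number 8.3 percentage points lower from compound 2 to compound 3 (within the scatter) lies within the usual scatter, so the two values cannot be ordered.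

Compound 4 `c1ccc(Cn2cnc3ccc(-c4nc(-c5cccc6ccccc56)cn5ccnc45)cc32)cc1` differs from compound 3 at one place: naphthalen-1-yl in place of 3-methylphenyl on an aromatic carbon. For the measured compounds named here, the only measured step that touches this position is a number 8.3 percentage points lower from compound 2 to compound 3 (within the scatter), and it did not rise above the scatter. Going by the values given here, no measured step involves a naphthalen-1-yl group, so the change itself gives no direction. The expectation for compound 4 is therefore a step of about a number 1.4 percentage points higher from compound 3 to compound 4 (within the scatter), which is no step beyond the scatter. Compound 4 is expected to give 8%, with a range from 0% to 22%.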

Compound 4, a percentage reported as inhibition, at one concentration (the size of the read-out at that concentration, not a potency): 1.83%
For compound 4 the middle estimate is 6.2 percentage points above the measured one, within the range that was stated.
By their numbers in this assay, from the lowest: compounds 4, 1, 3 and 2 (each within the scatter of the next, the first and the last beyond it).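

In this assay, naphthalen-1-yl in place of 3-methylphenyl gives a number 4.8 percentage points lower from compound 3 to compound 4 (within the scatter), so these two groups cannot be told apart. Naphthalen-1-yl in place of 4-ethylphenyl gives a number 13.1 percentage points lower from compound 2 to compound 4 (beyond the scatter), the only step at this position beyond the scatter and the first sign, though a modest one, that the aryl group on this aromatic carbon can change the read-out while the rest of the molecule stays the same. No measurement presented here accounts for this difference.

On these data alone, whether the same step would hold with the cyclohexyl group of compound 1 in place of the other substituent on the core remains open. So does the effect of a group of a different kind at this position, such as an amine or a carboxylic acid.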